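Nitro for Bromo on a Weakly Cytotoxic Core

The source may report more compounds than this note shows. Statements on the series, on what has been measured and on what is new or still open speak of the compounds shown alone.

Among the measured compounds shown here, compound 3 `CCn1c(/C=C2/C(=O)Nc3ccc(Br)cc32)nc2ccccc21` is the one member of this small set with a measured number: in a functional assay on 4T1 cells (Homo sapiens) for cytotoxicity, read by MTT assay, with a stated time of 48 h (on this read-out higher numbers stand for weaker inhibition and lower numbers for stronger inhibition), compound 3 gives 40700 nM. Its two companions did not reach a number. Compound 1 `CCn1c(/C=C2/C(=O)Nc3ccc(F)cc32)nc2ccccc21` carries a fluoro on the same aromatic carbon, and in this assay compound 1 gives only the limit > 50000 nM. Compound 2 `CCn1c(/C=C2/C(=O)Nc3ccccc32)nc2ccccc21` has hydrogen there, and in this assay compound 2 likewise gives the limit > 50000 nM. The exchange of fluoro for hydrogen is a step that the two limits leave unreadable from compound 1 to compound 2. The move to bromo is an at least 1.2-fold lower number from compound 1 to compound 3 (0.08 log units; that floor lies within the scatter) and an at least 1.2-fold lower number from compound 2 to compound 3 (0.08 log units; that floor lies within the scatter); these floors say little because the number for compound 3 lies close to the limit of > 50000 nM in this assay, at which 2 of the 3 values shown sit.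

Compound 4 `CCn1c(/C=C2/C(=O)Nc3ccc([N+](=O)[O-])cc32)nc2ccccc21` introduces the change (nitro in place of bromo on an aromatic carbon). For the measured compounds named here, no measured step exchanges bromo for nitro, and none of the measured steps reaches beyond the scatter, so they offer no direction for this exchange. The expectation for compound 4 is therefore a step of a 1.1-fold higher number from compound 3 to compound 4 (0.04 log units; within the scatter). The number for compound 4 is estimated at 45000 nM, between 15000 nM and 150000 nM, with a real chance that this assay again returns only a limit.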

Compound 4, half-maximal inhibitory concentration: > 50000 nM
Compound 4 was reported as a limit; the forecaster's own chance of this, stated with the estimate: 50%; at least 1.1-fold (0.04 log units) between middle value and limit.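

The exchange of bromo for nitro on this aromatic carbon gives an at least 1.2-fold higher number from compound 3 to compound 4 (0.08 log units; that floor lies within the scatter). Compound 4 is reported as a limit and not a number, as are compound 1 and compound 2, so the steps from compound 1 and from compound 2 to compound 4 cannot be read. Compound 3 therefore remains the only compound with a measured number, and the nitro group adds no readable information about this position, because the comparison is set against a ceiling that most of the series has reached: the limit of > 50000 nM in this assay, at which 3 of the 4 values shown sit.

The compounds shown leave open whether an amine or a carboxylic acid on this same aromatic carbon would return a number at all in this assay, and whether any such number would differ from that of compound 3 beyond the scatter. They also leave open whether a longer chain in place of the ethyl group on the shared core would bring the series away from this limit.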